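Loss of the methoxy group on the aryl substituent of compound 3

The source may report more compounds than this note shows. Statements on the series, on what has been measured and on what is new or still open speak of the compounds shown alone.

Measured compounds, half-maximal inhibitory concentration in a functional assay on MDA-MB-231 cells (Homo sapiens) for cytotoxicity, read by MTT assay, with a stated time of 72 h; on this read-out lower numbers stand for stronger inhibition and higher numbers for weaker inhibition:
- compound 1 `Fc1ccc(Nc2cc(Nc3ccc(Oc4ccncc4-c4cccnc4)c(F)c3)ncn2)cc1`: 14100 nM
- compound 2 `Cn1c(=O)c(C(=O)Nc2ccc(Oc3ccncc3-c3cccnc3)c(F)c2)nn(-c2ccc(F)c(Cl)c2)c1=O`: 11300 nM
- compound 3 `COc1ccc(-n2nc(C(=O)Nc3ccc(Oc4ccncc4-c4cccnc4)c(F)c3)c3ccccc3c2=O)cc1`: 10400 nM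

Compound 3 carries the lowest of the three numbers in this assay, but its gap to compound 2 and its gap to compound 1 both fall inside the usual scatter of repeated measurements, so the three compounds cannot be ordered against each other on these data. Among the measured compounds shown here, the three compounds share a common core and differ in the amide or amine cap attached to it; no pair of them differs in a single place, so no isolated step is available within the measured set.

Compound 4 `O=C(Nc1ccc(Oc2ccncc2-c2cccnc2)c(F)c1)c1nn(-c2ccccc2)c(=O)c2ccccc12` is the unmeasured analogue of compound 3. The change is hydrogen in place of methoxy on an aromatic carbon. With no measured step of this kind in the series, and the three caps already spanning a range that sits wholly within the scatter, the expectation is a small step, in either direction, not beyond the scatter. For compound 4 the expected step from compound 3 is a 1.2-fold higher number from compound 3 to compound 4 (0.06 log units; within the scatter). Compound 4 is therefore estimated at 12000 nM in this assay, with a range from 5000 nM to 30000 nM.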

Compound 4, half-maximal inhibitory concentration: 8200 nM
Beside the measured number, compound 4's estimate is 1.5-fold (0.17 log units) above it; the measured number falls inside the stated range.
By their numbers in this assay, from the lowest: compounds 4, 3, 2 and 1 (each within the scatter of the next).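

Among the compounds shown here, replacing 4-methoxyphenyl with phenyl gives the only single-place step: in this assay, it is a 1.3-fold lower number from compound 3 to compound 4 (0.10 log units; within the scatter). At this aromatic carbon, para to a large group, compound 3 and compound 4 therefore cannot be told apart, so the methoxy group shows no measurable contribution to the read-out on these data. No supporting measurement bears on this result, and the data offer no explanation for it.

Still open, going by these compounds, is whether an amine, a carboxylic acid or a longer alkoxy chain at this position would give a step beyond the scatter. For the compounds shown here, it is also open whether removing the methoxy group would read the same with a cap other than the one shared by compound 3 and compound 4.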